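The source may report more compounds than this note shows. Statements on the series, on what has been measured and on what is new or still open speak of the compounds shown alone.

Compound 1 `Cc1n[nH]cc1-c1cccc2c1CCC2c1ncc[nH]1` stands at the lowest number of the three in a functional assay on CHO cells for agonist activity at Alpha-1A adrenergic receptor (Homo sapiens), read by FLIPR and calcium flux (on this read-out higher numbers stand for an effect only at larger amounts of compound and lower numbers for an effect already at smaller amounts), where compound 1 gives 3 nM. Compound 2 `COc1cccc2c1CCC2c1ncc[nH]1` gives 32 nM, and compound 3 `Cn1nccc1-c1cccc2c1CCC2c1ncc[nH]1` gives 278 nM. Compound 4 `Cc1oncc1-c1cccc2c1CCC2c1ncc[nH]1` differs from compound 1 by 5-methyl-1,2-oxazol-4-yl in place of 3-methyl-1H-pyrazol-4-yl on an aromatic carbon. The measured steps that bear on this are an 11-fold higher number from compound 1 to compound 2 (1.03 log units; beyond the scatter) and a 93-fold higher number from compound 1 to compound 3 (1.97 log units; beyond the scatter); both replaced the same group on compound 1, and both raised the number well beyond the scatter. A rise is therefore expected for compound 4 as well, of a size between those two steps rather than as large as the step to compound 3. For compound 4 the expected step is an 8.3-fold higher number from compound 1 to compound 4 (0.92 log units; beyond the scatter). Compound 4 is estimated at 25 nM, with a range from 6 nM to 100 nM.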

Compound 4, half-maximal effective concentration: 111 nM
Estimate against measurement, compound 4: 4.4-fold (0.65 log units) below; the whole stated range lies below it.
By their numbers in this assay, from the lowest: compound 1; then compound 2; then compound 4; then compound 3.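

Replacing the 3-methyl-1H-pyrazol-4-yl with 5-methyl-1,2-oxazol-4-yl keeps a five-membered aromatic ring on this aromatic carbon, yet the number still rises sharply (a 37-fold higher number from compound 1 to compound 4 (1.57 log units; beyond the scatter)), so ring size alone does not preserve the result of compound 1. The replacement also separates itself from the other two groups (a 2.5-fold lower number from compound 3 to compound 4 (0.40 log units; beyond the scatter); a 3.5-fold higher number from compound 2 to compound 4 (0.54 log units; beyond the scatter)), which shows that the identity of the five-membered ring matters here. No available evidence explains these differences.

From the compounds shown here alone, whether the hydrogen-bond donor lost in this change matters remains open. So does how an unmethylated pyrazole or an amine would fare at this position.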